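Long-Chain Ureas Against Cholesterol Acyltransferase: A Dichlorophenyl Variant

A few compounds are considered here, and "the series" means these few. Any claim that something is new, unique, unknown or untested is made for them only; others in the source may bear on it.

Measured so far in an assay on microsomes from intestinal mucosa for inhibition of acyl-CoA:cholesterol acyltransferase (Oryctolagus cuniculus); on this read-out higher numbers stand for weaker inhibition and lower numbers for stronger inhibition:
compound 1 `CCCCCCCC/C=C\CCCCCCCC(=O)c1c(OC)cc(OC)cc1OC` gives > 50000 nM, a limit of the assay rather than a number.
compound 2 `CCCCCCCC/C=C\CCCCCCCCNC(=O)Nc1ccccc1` gives > 5000 nM, again a limit rather than a number.
compound 3 `CCCCCCCC/C=C\CCCCCCCCNC(=O)Nc1ccc(Oc2ccccc2)cc1` gives > 5000 nM, likewise a limit.

Compound 2 therefore stands only at a limit in this assay, and the other two values shown are limits as well (the limit of > 5000 nM in this assay, at which 2 of the 3 values shown sit, (the limit of > 50000 nM in this assay, at which 1 of the 3 values shown sits)). Among the measured compounds shown here, no compound here has a numerical value, so no ranking among them is possible.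

The step under study leads from compound 2 to compound 4 `CCCCCCCC/C=C\CCCCCCCCNC(=O)Nc1c(Cl)cccc1Cl`, which has not yet been measured. The change is 2,6-dichlorophenyl in place of phenyl on an amide-type nitrogen. For the measured compounds named here, only one measured step comes close to it: a step that the two limits leave unreadable from compound 2 to compound 3. Because both ends of that step are limits, its size cannot be read, and it concerns a phenoxy group rather than two chlorine atoms; it gives no direction and no size for the present change.

With compound 2 itself at a limit, any expectation for compound 4 rests on the shape of the change alone. The estimated step of an at least 2.5-fold lower number from compound 2 to compound 4 (0.39 log units; beyond the scatter) is a guess toward stronger inhibition that may not exceed the scatter. Compound 4 is therefore expected to give about 2000 nM, with a wide range from 300 nM to 15000 nM, and a real chance that only a limit is reported.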

Compound 4, half-maximal inhibitory concentration: 400 nM
Beside the measured number, compound 4's estimate is 5.0-fold (0.70 log units) above it; the range from low to high includes it.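

Among the compounds shown here, the change from phenyl to 2,6-dichlorophenyl on an amide-type nitrogen gives the first step in this set whose size can be judged in this assay: an at least 12-fold lower number from compound 2 to compound 4 (1.09 log units; beyond the scatter). For the compounds shown here, that figure is only a minimum, and the true step could be larger, because compound 2 stands at a limit rather than a number: the limit of > 5000 nM in this assay, at which 2 of the 4 values shown sit. Both ends of the other step, from compound 2 to compound 3, are limits, and it cannot be read; the pair of compound 2 and compound 4 is therefore the only direct evidence here that changing the aromatic group on this nitrogen can strengthen inhibition.

Both chlorine atoms enter together, so the compounds shown leave open whether a phenyl ring carrying a single chlorine would give a similar result, or whether methyl groups in place of the chlorine atoms would do the same. From the compounds shown here alone, the long unsaturated chain is also the same in compound 2 and compound 4, so it remains open whether the gain from 2,6-dichlorophenyl would survive with a shorter chain.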